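The source may hold more compounds than are shown below. What is called first, only, known or untested is meant among the compounds shown, and "the series" means these compounds.

Of the compounds shown here, three sharing one core have been measured in an assay on HEK293 cells for agonist activity at Toll-like receptor 8 (Homo sapiens), read by spectrophotometry; a lower number here means that less compound is needed, a higher number that more compound is needed for the effect. Compound 1 `CCCCNc1nc(N)nc(C)c1CCCc1ccccc1` gives 749 nM, compound 2 `CCCCCc1c(C)nc(N)nc1NCCCC` gives 1220 nM, and compound 3 `CCCCNc1nc(N)nc(C)c1CC` gives 1660 nM, the highest of the three numbers; its gap to compound 2 lies within the scatter, while a 2.2-fold higher number from compound 1 to compound 3 (0.35 log units; beyond the scatter) is a modest step beyond it. Compound 4 `CCCCNc1nc(N)nc(C)c1CCCN(CC)CC` differs from compound 3 in one place: (diethylamino)methyl in place of hydrogen on a saturated chain carbon, two bonds along the chain from an aromatic carbon. For the measured compounds named here, two measured steps concern the same place on the chain, a 1.4-fold higher number from compound 2 to compound 3 (0.13 log units; within the scatter) and a 2.2-fold higher number from compound 1 to compound 3 (0.35 log units; beyond the scatter). Taken together they suggest that adding a group there gives at most a modest shift in this assay, so for compound 4 a small downward step, or none beyond the scatter, is expected: a 1.7-fold lower number from compound 3 to compound 4 (0.22 log units; within the scatter). Compound 4 is estimated at 1000 nM, with a range from 400 nM to 2500 nM.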

Compound 4, half-maximal effective concentration: 254 nM
For compound 4 the middle estimate is 3.9-fold (0.60 log units) above the measured one; measured number outside the range, below it.
By their numbers in this assay, from the lowest: compound 4; then compounds 1, 2 and 3 (each within the scatter of the next, the first and the last beyond it).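

Placing (diethylamino)methyl on the saturated chain carbon, two bonds along the chain from an aromatic carbon, gives the largest step seen at this place in this assay (a 6.5-fold lower number from compound 3 to compound 4 (0.82 log units; beyond the scatter)). This place therefore responds to what the chain carries, not only to whether a chain is present: diethylamino at the chain end gives a lower number than ethyl (a 4.8-fold lower number from compound 2 to compound 4 (0.68 log units; beyond the scatter)) and than phenyl (a 2.9-fold lower number from compound 1 to compound 4 (0.47 log units; beyond the scatter)). Nothing measured here explains the difference. 

Still open, from the compounds shown here alone, is whether the nitrogen itself matters or the size of the group does. A dimethylamino group, a methoxy group or a longer chain carrying the same diethylamino group would help separate these.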